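Fluoro in place of hydrogen on the phenyl of compound 1

This account rests on a few compounds, and the source may have more. Where it says the series, first, only, none or still open, it means among the compounds named here.

Values in a functional assay on Jurkat cells for inhibition of nuclear factor NF-kappa-B complex (Homo sapiens) (on this read-out higher numbers stand for weaker inhibition and lower numbers for stronger inhibition), for the three measured compounds:
compound 1, `CCOC(=O)c1cnc(-c2ccccc2)nc1NN1C(=O)C=C(C)C1=O`: 100 nM
compound 2, `CCOC(=O)c1cnc(-c2csc(C)n2)nc1NN1C(=O)C=C(C)C1=O`: 8000 nM
compound 3, `CCOC(=O)c1cnc(-c2cccc(OC)c2)nc1NN1C(=O)C=C(C)C1=O`: 5000 nM

Compound 1 has the lowest number of the three. Its nearest neighbour is compound 3, reached by a 50-fold higher number from compound 1 to compound 3 (1.70 log units; beyond the scatter); the furthest is compound 2, reached by an 80-fold higher number from compound 1 to compound 2 (1.90 log units; beyond the scatter). Between compounds 2 and 3 the values lie close, a 1.6-fold lower number from compound 2 to compound 3 (0.20 log units; within the scatter).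

Compound 4, `CCOC(=O)c1cnc(-c2ccc(F)cc2)nc1NN1C(=O)C=C(C)C1=O`, is the next entry. Its difference from compound 1 is fluoro in place of hydrogen on an aromatic carbon.

Within the data shown here, only one measured step bears directly on this change: from compound 1 to compound 3 a single group also enters the phenyl ring, and the number rose sharply, a 50-fold higher number from compound 1 to compound 3 (1.70 log units; beyond the scatter). The step to compound 2 exchanges the whole ring and is less comparable. Among the measured compounds shown here, no measured step adds a group as small as fluoro, and no measured step adds a group at the place where it enters here, so the size of the effect is open. The entering group is far smaller than methoxy, so a rise is expected that stays well short of the step to compound 3.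

Compound 4 is therefore expected to give about 300 nM, within 80 nM to 2000 nM, which means an estimated 3.0-fold higher number from compound 1 to compound 4 (0.48 log units; beyond the scatter).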

Compound 4, half-maximal inhibitory concentration: 700 nM
The estimate for compound 4 lay 2.3-fold (0.37 log units) below the measured number, within the range that was stated.
By their numbers in this assay, from the lowest: compound 1; then compound 4; then compounds 3 and 2 (each within the scatter of the next).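

In this assay, the single fluoro para to a large group is enough to raise the number, with a 7.0-fold higher number from compound 1 to compound 4 (0.85 log units; beyond the scatter), so even the smallest entering group shown here does not leave the phenyl of compound 1 without cost. Among these compounds, the 4-fluorophenyl still keeps much of the advantage over the other two aryl groups, with a 7.1-fold lower number from compound 3 to compound 4 (0.85 log units; beyond the scatter) and an 11-fold lower number from compound 2 to compound 4 (1.06 log units; beyond the scatter), placing compound 4 in a middle position that the earlier compounds, with their one low value and two high values, did not show. The data shown give no account of why the number rises on this change.

Going by these compounds, compounds 3 and 4 differ in both the entering group and where it sits on the phenyl, so it remains open whether the larger rise seen with 3-methoxyphenyl follows from the methoxy group, from its place, or from both. Also open, on these data alone, is how chloro, methyl or an amine at the place taken by fluoro would read, and whether any group on this phenyl can give a lower number than compound 1 at 100 nM.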